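Anilide to sulfonamide swap on the aryl thiazole series

A few compounds are considered here, and "the series" means these few. Any claim that something is new, unique, unknown or untested is made for them only; others in the source may bear on it.

Compound 3 `O=C(Nc1cccc(-c2csc(NC(=O)c3ccc([N+](=O)[O-])o3)n2)c1)c1ccccc1` carries a benzamido group on an aromatic carbon; in an ADME assay on Vero cells (Chlorocebus sabaeus) for cytotoxicity, read by MTT assay, with a stated time of 72 h (a lower number here means a stronger inhibitor, a higher number a weaker inhibitor), compound 3 gives 50200 nM. Compound 2 `O=C(Nc1nc(-c2cccc(OC3CCCC3)c2)cs1)c1ccc([N+](=O)[O-])o1` carries a cyclopentyloxy group at that carbon, and in this assay compound 2 gives 81100 nM. Compound 1 `CCOc1cccc(-c2csc(NC(=O)c3ccc([N+](=O)[O-])o3)n2)c1` carries an ethoxy group there; in this assay compound 1 reaches only > 90000 nM, which is a limit of the assay and not a number (the limit of > 90000 nM in this assay, at which 1 of the 3 values shown sits). Compound 3 gives the lower of the two numbers, though its gap to compound 2 lies within the scatter, a 1.6-fold lower number from compound 2 to compound 3 (0.21 log units; within the scatter). Compound 4 `O=C(Nc1nc(-c2cccc(NS(=O)(=O)Cc3ccccc3)c2)cs1)c1ccc([N+](=O)[O-])o1` differs from compound 3 at one place: benzylsulfonyl in place of benzoyl on a nitrogen on an aromatic ring. Among the compounds with values here, the steps that bear on this change are the two swaps of the group on the same aromatic carbon, an at least 1.7-fold lower number from compound 1 to compound 3 (0.25 log units; that floor lies within the scatter) and a 1.6-fold lower number from compound 2 to compound 3 (0.21 log units; within the scatter), both within the scatter. Hence no step beyond the scatter is expected in this assay for compound 4, a 1.1-fold higher number from compound 3 to compound 4 (0.04 log units; within the scatter). Compound 4 is therefore estimated at 55000 nM, between 25000 nM and 120000 nM.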

Compound 4, half-maximal inhibitory concentration: 59300 nM
Estimate against measurement, compound 4: 1.1-fold (0.03 log units) below, within the range that was stated.
By their numbers in this assay, from the lowest: compounds 3, 4 and 2 (each within the scatter of the next). At a limit, above all of these: compound 1.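

In this assay, a sulfonamide link at this nitrogen is not told apart from the amide link: benzylsulfonyl in place of benzoyl on a nitrogen on an aromatic ring gives a 1.2-fold higher number from compound 3 to compound 4 (0.07 log units; within the scatter). Set against the ether groups on the same aromatic carbon, (benzylsulfonyl)amino gives a 1.4-fold lower number from compound 2 to compound 4 (0.14 log units; within the scatter) and an at least 1.5-fold lower number from compound 1 to compound 4 (0.18 log units; that floor lies within the scatter), so neither the sulfonyl link nor the benzyl group separates compound 4 from the other compounds with a number in this series. The value of compound 1 is a limit of the assay, and its step is therefore only a floor: the limit of > 90000 nM in this assay, at which 1 of the 4 values shown sits.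

From the compounds shown here alone, whether any group on this aromatic carbon moves the number beyond the scatter stays open. A free amine, a carboxylic acid or a longer alkyl chain on the sulfonyl could test this.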